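The source may report more compounds than this note shows. Statements on the series, on what has been measured and on what is new or still open speak of the compounds shown alone.

Measured in a functional assay on T98G cells (Homo sapiens) for inhibition, read by MTT assay, with a stated time of 72 h; on this read-out lower numbers stand for stronger inhibition and higher numbers for weaker inhibition:
- compound 1 `COc1ccccc1NC(=S)NC1CC(C)(C)Oc2ccc(Br)cc21`: 42000 nM
- compound 2 `COc1cccc(NC(=S)NC2CC(C)(C)Oc3ccc(Br)cc32)c1`: 87000 nM

Of these two numbers, the higher belongs to compound 2, at 87000 nM, so it shows the weaker inhibition of the pair. Compound 3 `CC1(C)CC(NC(=S)NCc2ccccc2)c2cc(Br)ccc2O1` keeps the shared core and the thiocarbonyl carbon, and it changes only the group on the amide-type nitrogen: benzyl in place of 3-methoxyphenyl on an amide-type nitrogen. Benzyl thus takes the place of 3-methoxyphenyl.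

Among the compounds with values here, only one measured step bears on this change, and it concerns the same nitrogen: a 2.1-fold higher number from compound 1 to compound 2 (0.32 log units; beyond the scatter). That step is modest, though beyond the scatter. Within the data shown here, it exchanges one methoxyphenyl group for another, and no measured compound carries benzyl, so the data give no firm direction for the new group. A large shift in this assay has no support from these two compounds, and a step of modest size at most is expected. The expected step is a 1.5-fold lower number from compound 2 to compound 3 (0.16 log units; within the scatter), which would stay within the scatter. For compound 3 the estimated value is 60000 nM, with an expected range from 25000 nM to 150000 nM.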

Compound 3, half-maximal inhibitory concentration: 54000 nM
Estimate against measurement, compound 3: 1.1-fold (0.05 log units) above; measured number inside the range.
By their numbers in this assay, from the lowest: compounds 1, 3 and 2 (each within the scatter of the next, the first and the last beyond it).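

Read in this assay, benzyl on the amide-type nitrogen gives a 1.6-fold lower number from compound 2 to compound 3 (0.21 log units; within the scatter) and a 1.3-fold higher number from compound 1 to compound 3 (0.11 log units; within the scatter), so compound 3 cannot be told apart from either methoxyphenyl compound, even though compound 1 and compound 2 differ from each other beyond the scatter. The earlier pair varied only the place of the methoxy group on the phenyl ring, whereas benzyl has no oxygen and no hydrogen-bond acceptor, and this exchange still produces no step beyond the scatter in these three compounds. No measurement shown here accounts for these readings.

The compounds shown leave open whether any group on this nitrogen can produce a large step, since all three carry a single six-membered aromatic ring of carbon only, and a longer chain such as phenethyl, a saturated group such as cyclohexyl, or a benzyl bearing an amine or a carboxylic acid would each probe a different kind of substituent. They also leave open how the number would respond to a change elsewhere, such as a carbonyl in place of the thiocarbonyl or chlorine in place of the bromine on the shared core.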